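The source may report more compounds than this note shows. Statements on the series, on what has been measured and on what is new or still open speak of the compounds shown alone.

Compound 1 (`CCN(CC)c1ccc(/C=N/NC(=O)c2ccc([N+](=O)[O-])cc2)c(O)c1`) gives 2500 nM
Compound 2 (`CC(C)(C)c1ccc(O)c(/C=N/NC(=O)c2ccccc2)c1`) gives 2600 nM

In a functional assay on MRC5 cells (Homo sapiens) for cytotoxicity, read by colorimetric assay and MTT assay (a lower number here means that less compound is tolerated, a higher number that more compound is tolerated), compound 2 stands level with compound 1, their two numbers lying within the usual scatter of repeated measurements. Compound 3 (`CC(C)(C)c1ccc(O)c(/C=N/NC(=O)c2ccc(Cl)cc2)c1`) has not yet been measured. It departs from compound 2 by one change (chloro in place of hydrogen on an aromatic carbon): chloro in place of hydrogen on an aromatic carbon, para to a large group, so that phenyl becomes 4-chlorophenyl. For the measured compounds named here, no measured pair of compounds shows a step of this kind, so the expectation rests only on compound 2 at 2600 nM and on compound 1 at 2500 nM as the sole reference points. The step of a 1.3-fold lower number from compound 2 to compound 3 (0.11 log units; within the scatter) is expected to be small and towards a somewhat lower number in this assay and may well stay within the scatter. In this assay compound 3 is estimated at 2000 nM (expected range from 900 nM to 4500 nM).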

Compound 3, half-maximal cytotoxic concentration: 3600 nM
The estimate for compound 3 lay 1.8-fold (0.26 log units) below the measured number; measured number inside the range.
By their numbers in this assay, from the lowest: compounds 1, 2 and 3 (each within the scatter of the next).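

In this assay, the exchange of hydrogen for chloro on an aromatic carbon, para to a large group, gives a 1.4-fold higher number from compound 2 to compound 3 (0.14 log units; within the scatter). For the compounds shown here, this is the only step that can be read so far, and it shows that turning phenyl into 4-chlorophenyl does not separate compound 3 from compound 2 beyond the usual scatter of repeated measurements, so this single chlorine atom leaves the number in this assay effectively where it stood. No measurement shown here offers an explanation for this result.

What the compounds shown leave open is whether this position stays as undemanding with other groups, since an amine, a carboxylic acid or a longer chain on the same aromatic carbon might give a step beyond the scatter, or might again give none. Also open, from the compounds shown here alone, is whether chloro would give a similar step on another core, because compound 1 differs from compound 2 in more than one place and so offers no second reading of this change.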